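This account rests on a few compounds, and the source may have more. Where it says the series, first, only, none or still open, it means among the compounds named here.

Within the data shown here, compound 1 `CCn1cc(COc2cc(O)c3c(c2)O[C@H](c2ccc(OC)c(O)c2)C/C3=N\O)nn1` is one of two compounds measured in a functional assay on RAW264.7 cells (Mus musculus) for inhibition, read by Griess assay, with stated times of 2 h and 24 h; on this read-out higher numbers stand for weaker inhibition and lower numbers for stronger inhibition. In this assay compound 1 gives 3140 nM, the lower of the two numbers. The other measured compound, compound 2 `C#CCOc1cc(O)c2c(c1)O[C@H](c1ccc(OC)c(O)c1)CC2=O`, gives in this assay 20900 nM, a number well beyond the scatter above that of compound 1, so compound 1 is the stronger inhibitor of the two on this read-out.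

Compound 3 `C#CCOc1cc(O)c2c(c1)O[C@H](c1ccc(OC)c(O)c1)C/C2=N\O` has not been measured. It differs from compound 1 in one place: ethynyl in place of 1-ethyl-1H-1,2,3-triazol-4-yl on a saturated chain carbon bound to an oxygen on an aromatic ring. Among the measured compounds shown here, no measured pair shows this particular exchange, so the size of the step can only be expected, not read from a measured step. The step from compound 1 to compound 3 is expected to go toward weaker inhibition, estimated as a 2.5-fold higher number from compound 1 to compound 3 (0.41 log units; beyond the scatter), a moderate step that may or may not clear the scatter. The expected number for compound 3 in this assay is 8000 nM, with a range from 2500 nM to 25000 nM.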

Compound 3, half-maximal inhibitory concentration: 19100 nM
Beside the measured number, compound 3's estimate is 2.4-fold (0.38 log units) below it; measured number inside the range.
By their numbers in this assay, from the lowest: compound 1; then compounds 3 and 2 (each within the scatter of the next).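

Among these compounds, at the saturated chain carbon bound to an oxygen on an aromatic ring, the exchange of 1-ethyl-1H-1,2,3-triazol-4-yl for ethynyl in this assay gives a 6.1-fold higher number from compound 1 to compound 3 (0.78 log units; beyond the scatter), the first measured step at this position, and it shows that the stronger inhibition of the pair goes with the triazole-bearing group. The change also alters how the earlier gap reads, since compound 3 gives 19100 nM and compound 2 gives 20900 nM, values within the scatter of each other, so only compound 1 stands apart from the rest on this read-out. Nothing available explains why the larger group goes with the lower number, and the size of this step remains without an account.

The compounds shown rest on this single exchange, so they leave open whether the triazole ring itself or its ethyl group carries the difference. A propyl or benzyl group on the triazole, or a carboxylic acid or an amine at the end of the chain, could separate these two readings.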